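A few compounds are considered here, and "the series" means these few. Any claim that something is new, unique, unknown or untested is made for them only; others in the source may bear on it.

Compound 1 `COc1cc2c(Nc3ccc(C#N)cc3)ncnc2cc1OCCCN1CCCC1` is the reference point here. Going by the values given here, in a functional assay on MCF7 cells (Homo sapiens) for antiproliferative activity, read by MTT assay, with a stated time of 72 h (a lower number here means a stronger inhibitor, a higher number a weaker inhibitor), compound 1 gives 16200 nM, which is the only plain number among the values shown. Compound 2 `COc1cc2c(Nc3ccc(C#N)cc3)ncnc2cc1OCCCN1CCC(O)CC1` was tested in the same way, and for compound 2 the result is a limit, > 100000 nM, rather than a number. Among the compounds with values here, the single measured step, an at least 6.1-fold higher number from compound 1 to compound 2 (0.79 log units; beyond the scatter), therefore points toward weaker inhibition, and the step rests on (the limit of > 100000 nM in this assay, at which 1 of the 2 values shown sits).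

Compound 3 `COc1cc2c(Nc3ccc(C#N)cc3)ncnc2cc1OCCCN1CCN(c2ccncc2)CC1` has not yet been measured. It differs from compound 1 in one place: 4-(pyridin-4-yl)piperazin-1-yl in place of pyrrolidin-1-yl on a saturated chain carbon, three bonds along the chain from an oxygen on an aromatic ring. Within the data shown here, the only measured step that bears on this change is the one from compound 1 to compound 2, where a different, larger ring also took the place of pyrrolidin-1-yl at the same position and the number rose by at least a modest amount. On that basis the expectation for compound 3 in this assay is a step of a 2.5-fold higher number from compound 1 to compound 3 (0.39 log units; beyond the scatter) toward weaker inhibition. The estimated value for compound 3 is therefore 40000 nM, expected to fall between 12000 nM and 130000 nM.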

Compound 3, half-maximal inhibitory concentration: 22900 nM
Beside the measured number, compound 3's estimate is 1.7-fold (0.24 log units) above it, and the stated range covers the measured number.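

In this assay, putting 4-(pyridin-4-yl)piperazin-1-yl in place of pyrrolidin-1-yl on the saturated chain carbon gives a 1.4-fold higher number from compound 1 to compound 3 (0.15 log units; within the scatter), so this much larger group, with 12 heavy atoms against 5, leaves the reading where it was. Compound 2 therefore cannot be read as showing that any larger group at this position gives a weaker result, and the two larger groups clearly part ways, with an at least 4.3-fold lower number from compound 2 to compound 3 (0.64 log units; beyond the scatter). That step gives only a minimum size, because compound 2 has a limit and not a plain number: the limit of > 100000 nM in this assay, at which 1 of the 3 values shown sits.

The compounds shown leave open whether the weak result of compound 2 goes with its hydroxyl or with its six-membered ring, a question that a plain piperidin-1-yl at this position would help to settle. They also leave open whether any change here can bring the number clearly below that of compound 1, as a morpholin-4-yl group or a longer chain might or might not do.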